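The compounds below may be only part of what the source reports. "The series", "measured", "known", "first", "only" and "open" are said of these compounds alone.

Working notes on a urea series measured in a functional assay on A2780 cells (Homo sapiens) for inhibition, with a stated time of 72 h; on this read-out higher numbers stand for weaker inhibition and lower numbers for stronger inhibition.

Compound 1 `CCC1(CC)CC(C)(C)Oc2ccc(NC(=O)Nc3ccc(C(F)(F)F)cc3)cc21` gives 2430 nM in this assay. Two further compounds share the urea but carry a different core: compound 3 `CC1(C)CC(C)(C)c2cc(NC(=O)Nc3ccc(C(F)(F)F)cc3)ccc2O1` gives 3600 nM, and compound 2 `CC1(C)CC(C)(C)c2cc(NC(=O)Nc3ccc([N+](=O)[O-])cc3)ccc2O1` gives 4100 nM. The difference between the core of compound 1 and the core of compound 3 is not broken down here; the two values sit close together.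

Within the second core, compound 3 to compound 2 is a single change, (nitro in place of trifluoromethyl on an aromatic carbon), and it carries a 1.1-fold higher number from compound 3 to compound 2 (0.06 log units; within the scatter). The same change is made on the core of compound 1 to give compound 4 `CCC1(CC)CC(C)(C)Oc2ccc(NC(=O)Nc3ccc([N+](=O)[O-])cc3)cc21`, which has not yet been measured: nitro in place of trifluoromethyl on an aromatic carbon. The place described for both changes reads the same, so this counts as the same change, not only the same kind.

The expected step is a 1.1-fold higher number from compound 1 to compound 4 (0.05 log units; within the scatter), estimated from compound 3 to compound 2 because a 1.1-fold higher number from compound 3 to compound 2 (0.06 log units; within the scatter) shows the change leaving the number essentially where it was. Compound 4 is therefore expected to give about 2700 nM in this assay, estimated between 1400 nM and 5200 nM.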

Compound 4, half-maximal inhibitory concentration: 2050 nM
Estimate against measurement, compound 4: 1.3-fold (0.12 log units) above; low and high end bracket the measured number.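

Nitro in place of trifluoromethyl gives a 1.2-fold lower number from compound 1 to compound 4 (0.07 log units; within the scatter) in this assay, so on the core of compound 1 the change leaves the number essentially where it was. Set beside the same change on the second core, the two steps agree, and on these two cores the change carries over as a step too small to separate from the scatter: the same change on two cores in this assay, a 1.1-fold higher number (0.06 log units; within the scatter) from compound 3 to compound 2 and a 1.2-fold lower number (0.07 log units; within the scatter) from compound 1 to compound 4, 1.4-fold (0.13 log units) apart, within the scatter of two such steps. Going by these compounds alone, this shows only that the swap is neutral on both cores; it does not show that a change with a larger effect would carry over equally well, and two cores give no basis for a rule across the series.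

The compounds shown leave open whether another group in that place, such as an amine, a carboxylic acid or a nitrile, would move the number beyond the scatter. They also leave open whether an amide in place of the urea would keep a number of this order on either core.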